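Replacing 4-(dimethylamino)phenyl with 2,4-dichlorophenyl

A few compounds are considered here, and "the series" means these few. Any claim that something is new, unique, unknown or untested is made for them only; others in the source may bear on it.

In a functional assay on HepG2 cells (Homo sapiens) for antiproliferative activity, read by MTT assay, with a stated time of 48 h (a higher number here means a weaker inhibitor, a lower number a stronger inhibitor), compound 2 `CN(C)c1ccc(NC(=O)Nc2cccc(CNc3nccnc3Cl)c2)cc1` gives > 40000 nM, which is a limit of the assay and not a number. Its standing on the data is therefore only (the limit of > 40000 nM in this assay, at which 1 of the 2 values shown sits). Among the compounds with values here, compound 1 `O=C(Nc1ccc(Cl)cc1)Nc1cccc(CNc2nccnc2Cl)c1`, the one comparison available, gives 8350 nM in this assay. Within the data shown here, the single measured step is an at least 4.7-fold higher number from compound 1 to compound 2 (0.68 log units; beyond the scatter), with dimethylamino in place of chloro on an aromatic carbon, and it lies beyond the scatter.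

In compound 3 `O=C(Nc1cccc(CNc2nccnc2Cl)c1)Nc1ccc(Cl)cc1Cl`, 2,4-dichlorophenyl stands in place of 4-(dimethylamino)phenyl on an amide-type nitrogen (2,4-dichlorophenyl in place of 4-(dimethylamino)phenyl on an amide-type nitrogen). This removes the dimethylamino group and restores chloro, so the measured step of an at least 4.7-fold higher number from compound 1 to compound 2 (0.68 log units; beyond the scatter) is expected to run roughly in reverse. No measured compound carries the 2,4-dichlorophenyl group, and the expected range is kept wide for that reason. The expected change is an at least 6.6-fold lower number from compound 2 to compound 3 (0.82 log units; beyond the scatter), toward a lower number and beyond the scatter. Compound 3 is estimated at 6000 nM in this assay, with an expected range from 2000 nM to 20000 nM.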

Compound 3, half-maximal inhibitory concentration: 7230 nM
For compound 3 the middle estimate is 1.2-fold (0.08 log units) below the measured one; measured number inside the range.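

In this assay, the change on the amide-type nitrogen gives an at least 5.5-fold lower number from compound 2 to compound 3 (0.74 log units; beyond the scatter), so the shared core can read well below the limit of the assay once 2,4-dichlorophenyl replaces 4-(dimethylamino)phenyl, and the weak result belongs to the dimethylamino-bearing group rather than to the core. The size of that step is only a lower bound, since compound 2 has a limit of the assay and not a number: the limit of > 40000 nM in this assay, at which 1 of the 3 values shown sits. Adding chloro in place of hydrogen on an aromatic carbon gives a 1.2-fold lower number from compound 1 to compound 3 (0.06 log units; within the scatter), which lies within the scatter, so the two chlorinated compounds cannot be told apart here and the extra chloro shows no measurable effect in this assay.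

The compounds shown carry only chloro and dimethylamino on this ring, so it stays open whether a methoxy group, a trifluoromethyl group or a plain phenyl would read like compound 1 and compound 3 or like compound 2. On these data alone, it also stays open whether another amine, such as morpholine, or a carboxylic acid at this place would share the result of compound 2.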